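The source may hold more compounds than are shown below. What is called first, only, known or untested is meant among the compounds shown, and "the series" means these compounds.

Measured compounds:
- compound 1 `COC(=O)c1cc(-n2cc(-c3cc(O)ccc3O)nn2)ccc1O`: 52%
- compound 2 `COc1ccccc1-c1cn(-c2ccc(O)c(C(=O)Nc3cccc(C(F)(F)F)c3)c2)nn1`: 65%
- compound 3 `COc1ccc(-c2cn(-c3ccc(O)c(C(=O)O)c3)nn2)cc1`: 9%

All three were tested in a functional assay on CCRF-CEM cells (Homo sapiens) for inhibition, read by MTT assay, with a stated time of 2 days, tested at 10 uM; a lower number here means less inhibition, a higher number more inhibition at the concentration tested (going by the name of the read-out). Compound 3 stands lowest of the three: compound 1 sits well above it, and compound 2 higher still, both gaps being beyond the usual scatter. Compound 4 `COC(=O)c1cc(-n2cc(-c3ccc(OC)cc3)nn2)ccc1O` has not yet been measured. It differs from compound 3 in one place only: methyl in place of hydrogen on an oxygen next to a carbonyl group, that is, carboxy becomes methoxycarbonyl. Compound 1 also carries a methoxycarbonyl group and gives a far higher number than compound 3, which suggests the change may matter. Among the measured compounds shown here, the step from compound 3 to compound 4 is therefore expected to be upward, a number 31 percentage points higher from compound 3 to compound 4 (beyond the scatter), beyond the scatter, though only one comparison supports this. Compound 4 is estimated at 40%, within 15% to 65%.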

Compound 4, a percentage reported as inhibition, at one concentration (the size of the read-out at that concentration, not a potency): 16%
The estimate for compound 4 lay 24 percentage points above the measured number; low and high end bracket the measured number.
By their numbers in this assay, from the lowest: compounds 3 and 4 (each within the scatter of the next); then compound 1; then compound 2.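

In this assay, the step of a number 7 percentage points higher from compound 3 to compound 4 (within the scatter) comes with carboxy becoming methoxycarbonyl, so this change alone does not clearly alter the number when 4-methoxyphenyl is present. The step of a number 36 percentage points lower from compound 1 to compound 4 (beyond the scatter) comes with 4-methoxyphenyl in place of 2,5-dihydroxyphenyl, so methoxycarbonyl alone does not secure the higher number of compound 1. Nothing measured here explains either step.

Still open, on these data alone, is whether an ethyl group on that oxygen would read differently from methyl. Also open is whether both hydroxy groups of 2,5-dihydroxyphenyl are needed, as no compound shown carries a hydroxyphenyl group with only one.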